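Arylsulfonyl for benzoyl on the shared core

A few compounds are considered here, and "the series" means these few. Any claim that something is new, unique, unknown or untested is made for them only; others in the source may bear on it.

Measured compounds in a functional assay on 143B cells (Homo sapiens) for antiproliferative activity, read by MTT assay, with a stated time of 48 h; on this read-out lower numbers stand for stronger inhibition and higher numbers for weaker inhibition:
Compound 1 `O=C(Nc1cccc(/C=C/C(=O)c2nc3ccccc3[nH]2)c1)c1ccccc1` gives 8340 nM.
Compound 2 `O=C(/C=C/c1cccc(NC(=O)c2ccccc2Br)c1)c1nc2ccccc2[nH]1` gives 6050 nM.
Compound 3 `O=C(/C=C/c1cccc(NS(=O)(=O)c2ccc(Cl)cc2)c1)c1nc2ccccc2[nH]1` gives 7450 nM.

Compound 1 has the highest of the three numbers in this assay, but all three sit within the scatter of one another: the step of a 1.4-fold lower number from compound 1 to compound 2 (0.14 log units; within the scatter) and the step of a 1.1-fold lower number from compound 1 to compound 3 (0.05 log units; within the scatter) are both small, and so is the step of a 1.2-fold higher number from compound 2 to compound 3 (0.09 log units; within the scatter). Nothing in the set so far separates the three compounds.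

Compound 4 `Cc1cccc(S(=O)(=O)Nc2cccc(/C=C/C(=O)c3nc4ccccc4[nH]3)c2)c1` differs from compound 1 in one place: (3-methylphenyl)sulfonyl in place of benzoyl on a nitrogen on an aromatic ring. Within the data shown here, the closest precedent is the step from compound 1 to compound 3, which also exchanges benzoyl for an arylsulfonyl on the same nitrogen and moved the number only within the scatter, a 1.1-fold lower number from compound 1 to compound 3 (0.05 log units; within the scatter). Among the measured compounds shown here, the set holds no step that varies a methyl on the entering aryl ring, so the only guidance is that exchange of the acyl for a sulfonyl left the read-out essentially unchanged. No step beyond the scatter in this assay is therefore expected for compound 4 in either direction.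

Compound 4 is expected to come in at 7500 nM, with a range from 3500 nM to 16000 nM, which corresponds to an expected step of a 1.1-fold lower number from compound 1 to compound 4 (0.05 log units; within the scatter).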

Compound 4, half-maximal inhibitory concentration: 791 nM
For compound 4 the middle estimate is 9.5-fold (0.98 log units) above the measured one; measured number below the stated range.
By their numbers in this assay, from the lowest: compound 4; then compounds 2, 3 and 1 (each within the scatter of the next).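

In this assay, an arylsulfonyl on this nitrogen does not by itself leave the read-out unchanged: an 11-fold lower number from compound 1 to compound 4 (1.02 log units; beyond the scatter) stands against a 1.1-fold lower number from compound 1 to compound 3 (0.05 log units; within the scatter), although both steps put an arylsulfonyl in place of benzoyl. Between the two sulfonamides, the aryl group on the sulfonyl sulfur is what differs, and 3-methylphenyl in place of 4-chlorophenyl gives a 9.4-fold lower number from compound 3 to compound 4 (0.97 log units; beyond the scatter), so this position responds to the aryl group as well as to the linking sulfonyl or carbonyl. The step to the bromo amide points the same way, with a 7.6-fold lower number from compound 2 to compound 4 (0.88 log units; beyond the scatter) setting compound 4 clearly apart from all three earlier compounds, but no measurement available here accounts for the gain.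

The step from compound 3 to compound 4 changes both the substituent and where it sits on the aryl ring, so the compounds shown cannot say whether the methyl group, its placement or the loss of chloro matters; 4-methylphenyl, 3-chlorophenyl and unsubstituted phenyl on the sulfonyl would separate these. Also open, going by these compounds, is how this position responds to an amine, a carboxylic acid or a longer alkyl chain on that ring.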